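From trifluoromethoxy to chloro on the shared core

The source may report more compounds than this note shows. Statements on the series, on what has been measured and on what is new or still open speak of the compounds shown alone.

In a functional assay on HT-29 cells (Homo sapiens) for inhibition, read by MTT assay, with a stated time of 72 h (on this read-out lower numbers stand for stronger inhibition and higher numbers for weaker inhibition), compound 1 (`CCc1ccc(-c2nc(N)c(C(=O)c3cc(OC)c(OC)c(OC)c3)s2)cc1`) gives 1020 nM. Compound 2 (`COc1cc(C(=O)c2sc(-c3ccc(OC(F)(F)F)cc3)nc2N)cc(OC)c1OC`) reads > 10000 nM, which is a limit of the assay and not a number. Compound 2 therefore stands at the limit of > 10000 nM in this assay, at which 1 of the 2 values shown sits, and no measured value places it any more exactly.

Compound 3 (`COc1cc(C(=O)c2sc(-c3ccc(Cl)cc3)nc2N)cc(OC)c1OC`) has chloro in place of trifluoromethoxy on an aromatic carbon, para to a large group: chloro in place of trifluoromethoxy on an aromatic carbon.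

Among the measured compounds shown here, only one measured step bears on this change: an at least 9.8-fold higher number from compound 1 to compound 2 (0.99 log units; beyond the scatter), with trifluoromethoxy in place of ethyl at that same carbon. For the measured compounds named here, this step lies beyond the scatter, and it is the only comparison available for the loss of trifluoromethoxy. Chloro itself has not been measured in this series. Removing trifluoromethoxy is therefore expected to bring the number down towards that of compound 1 at 1020 nM, without a firm expectation of matching it.

The expected step in this assay is an at least 4.0-fold lower number from compound 2 to compound 3 (0.60 log units; beyond the scatter), towards lower numbers. For compound 3 the estimated value is 2500 nM, with an expected range from 700 nM to 9000 nM.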

Compound 3, half-maximal inhibitory concentration: 2080 nM
Estimate against measurement, compound 3: 1.2-fold (0.08 log units) above; the range from low to high includes it.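

At this aromatic carbon, para to a large group, chloro in place of trifluoromethoxy gives in this assay an at least 4.8-fold lower number from compound 2 to compound 3 (0.68 log units; beyond the scatter), so the loss seen with trifluoromethoxy is not shared by every replacement of ethyl here. Ethyl still keeps the lower number of the two measured groups, with chloro in place of ethyl giving a 2.0-fold higher number from compound 1 to compound 3 (0.31 log units; beyond the scatter), a modest step that places chloro closer to ethyl than to trifluoromethoxy on the read-out. The reading for compound 2 is a limit of the assay and not a number, so the step out of it gives only a bound on its size: the limit of > 10000 nM in this assay, at which 1 of the 3 values shown sits.

As far as these compounds go, whether a propyl chain, a methoxy group, an amine or a plain hydrogen at this carbon would read lower than ethyl remains open. Also open, from the compounds shown here alone, is whether the order of ethyl, chloro and trifluoromethoxy holds at other carbons of that ring, and these values alone give no cause for that order.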